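Triazole substituent swap on the shared core

The compounds below may be only part of what the source reports. "The series", "measured", "known", "first", "only" and "open" are said of these compounds alone.

Measured in an ADME assay on HEK293 cells (Homo sapiens) for cytotoxicity, read by sulforhodamine B assay, with a stated time of 48 h, tested at 10 uM; a lower number here means less inhibition, a higher number more inhibition at the concentration tested (going by the name of the read-out):
- compound 1, `COc1nc2ccc(Br)cc2cc1C(c1ccccc1)n1cc(-c2ccccc2F)nn1`: 3.97%
- compound 2, `CCCCCCCCc1cn(C(c2ccccc2)c2cc3cc(Br)ccc3nc2OC)nn1`: 14.6%
- compound 3, `CCCc1cn(C(c2ccccc2)c2cc3cc(Br)ccc3nc2OC)nn1`: 0.85%

Compound 2 stands highest of the three numbers shown, and its separation from each of the other two is beyond the scatter: a number 10.6 percentage points higher from compound 1 to compound 2 (beyond the scatter) and a number 13.8 percentage points lower from compound 2 to compound 3 (beyond the scatter). Compound 1 and compound 3 sit close together, as a number 3.1 percentage points lower from compound 1 to compound 3 (within the scatter) shows a difference within the scatter.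

The next compound, compound 4 `COc1nc2ccc(Br)cc2cc1C(c1ccccc1)n1cc(-c2ccc(OC(F)(F)F)cc2)nn1`, differs from compound 2 by 4-(trifluoromethoxy)phenyl in place of octyl on an aromatic carbon.

Both measured steps away from the octyl compound bear on this change. The step of a number 10.6 percentage points higher from compound 1 to compound 2 (beyond the scatter) runs in the opposite direction to the change at hand and was modest; the step of a number 13.8 percentage points lower from compound 2 to compound 3 (beyond the scatter) was likewise modest. Taken together, the octyl compound is the outlier on the high side, and the two compounds without octyl lie within the scatter of each other. For the measured compounds named here, compound 1 is the only measured compound carrying a six-membered aromatic ring at this carbon, so the expectation rests chiefly on it.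

A modest drop is therefore expected, a number 9.6 percentage points lower from compound 2 to compound 4 (within the scatter). For compound 4 the estimate is 5%, with a range from -4% to 14%.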

Compound 4, a percentage reported as inhibition, at one concentration (the size of the read-out at that concentration, not a potency): 5.8%
Compound 4: the middle estimate sits 0.8 percentage points below what was measured; measured number inside the range.
By their numbers in this assay, from the lowest: compounds 3, 1, 4 and 2 (each within the scatter of the next, the first and the last beyond it).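

In this assay, replacing one aryl group with another on this carbon of the five-membered aromatic ring gives a number 1.8 percentage points higher from compound 1 to compound 4 (within the scatter), so 4-(trifluoromethoxy)phenyl and 2-fluorophenyl cannot be told apart here, despite the added heavy atoms and the hydrogen-bond acceptor of the former. The same group set against the shorter chain gives a number 5 percentage points higher from compound 3 to compound 4 (within the scatter), and set against the longer chain it gives a number 8.8 percentage points lower from compound 2 to compound 4 (within the scatter), so compound 1, compound 3 and compound 4 now form one group within the scatter, while compound 2 stands beyond the scatter only from compound 1 and compound 3 and no longer from every other compound. No measurement at hand offers an explanation for these numbers.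

The compounds shown leave open whether a chain longer than octyl would separate clearly from the aryl compounds, and whether a terminal amine or carboxylic acid on a chain at this carbon would shift the number at all. Going by these compounds, each number is also a reading at one concentration, so how these compounds compare across a range of concentrations remains open.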